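Swapping the Aryl Group on the Sulfonyl Sulfur Once More

A few compounds are considered here, and "the series" means these few. Any claim that something is new, unique, unknown or untested is made for them only; others in the source may bear on it.

Compound 2 `COc1cc2c(Oc3ccc(NS(=O)(=O)c4cc(-c5ccsc5)ccc4F)cc3F)ccnc2cc1OCCCN1CCN(C)CC1` gives 4100 nM in a functional assay on NCI-H1975 cells (Homo sapiens) for cytotoxicity, read by MTT assay, with a stated time of 48 h (a higher number here means a weaker inhibitor, a lower number a stronger inhibitor), the lower of the two numbers seen so far, though compound 1 `COc1cc2c(Oc3ccc(NS(=O)(=O)c4cccc(-c5cnn(C)c5)c4)cc3F)ccnc2cc1OCCCN1CCN(C)CC1` with 6120 nM lies within the scatter of it, as the step of a 1.5-fold lower number from compound 1 to compound 2 (0.17 log units; within the scatter) shows. Compound 3 `COc1cc2c(Oc3ccc(NS(=O)(=O)c4cccc(-c5ccco5)c4)cc3F)ccnc2cc1OCCCN1CCN(C)CC1` differs from compound 2 only by 3-(furan-2-yl)phenyl in place of 2-fluoro-5-(thiophen-3-yl)phenyl on a sulfonyl sulfur. Going by the values given here, the single earlier step that bears on this change, from compound 1 to compound 2, also swapped the aryl group on the sulfonyl sulfur and stayed within the scatter, so no shift beyond the scatter is expected in this assay for compound 3 either. Compound 3 is therefore estimated at 5000 nM, between 2000 nM and 12500 nM, an expected step of a 1.2-fold higher number from compound 2 to compound 3 (0.09 log units; within the scatter).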

Compound 3, half-maximal inhibitory concentration: 1620 nM
For compound 3 the middle estimate is 3.1-fold (0.49 log units) above the measured one, and the stated range ends above it.
By their numbers in this assay, from the lowest: compound 3; then compounds 2 and 1 (each within the scatter of the next).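

In this assay the aryl group on the sulfonyl sulfur now proves able to shift the number: the step of a 2.5-fold lower number from compound 2 to compound 3 (0.40 log units; beyond the scatter) lies beyond the scatter, unlike the earlier swap. With the phenyl ring kept and only its five-membered ring exchanged, furan-2-yl in place of 1-methyl-1H-pyrazol-4-yl gives a 3.8-fold lower number from compound 1 to compound 3 (0.58 log units; beyond the scatter) and so counts on its own. Nothing measured here explains either gain.

Fluorine and thiophen-3-yl leave together in the step to compound 3, so their separate shares stay open. Also open, from the compounds shown here alone, is how an amine or a carboxylic acid on that phenyl ring would fare.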